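The source may report more compounds than this note shows. Statements on the series, on what has been measured and on what is new or still open speak of the compounds shown alone.

Of the compounds shown here, two built on one shared core have been measured. Compound 1 `CCCCNc1nc(N)nc2c1CCN(C)C2` carries a methyl on the ring nitrogen, while compound 2 `CCCCNc1nc(N)nc2c1CN(C(C)=O)CC2` carries an acetyl there instead. In an assay on HEK293 cells for agonist activity at Toll-like receptor 8 (Homo sapiens), read by a luciferase reporter, with a stated time of 6 h (a lower number here means that less compound is needed, a higher number that more compound is needed for the effect), compound 1 gives 0.2 uM. In this assay compound 2 gives 0.5 uM, the higher of the two numbers, and its gap to compound 1 lies beyond the usual scatter of this measurement, so compound 2 needs more material for the same effect.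

Compound 3 `CCCCNc1nc(N)nc2c1CN(C(=O)c1ccccn1)CC2` has not yet been measured. It differs from compound 2 in a single place: pyridin-2-yl in place of methyl on a carbonyl carbon. For the measured compounds named here, no pair of measured compounds differing in one place is available, so the size of this step can only be guessed. The step of a 1.7-fold lower number from compound 2 to compound 3 (0.22 log units; within the scatter) is expected to be small, with a slightly lower number as the more likely direction, and probably within the scatter. Compound 3 is therefore estimated to give about 0.3 uM in this assay, with a range from 0.08 uM to 1.2 uM.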

Compound 3, minimum effective concentration: 2.9 uM
Estimate against measurement, compound 3: 9.7-fold (0.99 log units) below; the whole stated range lies below it.
By their numbers in this assay, from the lowest: compound 1; then compound 2; then compound 3.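

In this assay putting pyridin-2-yl in place of methyl on a carbonyl carbon brings a 5.8-fold higher number from compound 2 to compound 3 (0.76 log units; beyond the scatter) and so calls for more compound to reach the effect. For the compounds shown here, this is the first step measured at this place, and it shows that the group on this carbonyl carbon, whose other neighbour is an amide-type nitrogen in a ring, can move the number beyond the usual scatter. Going from acetyl to (pyridin-2-yl)carbonyl is therefore not a neutral swap here, although a single step gives only one direction at one place and sets no general rule. Nothing at hand says what lies behind this shift.

The change adds an aromatic ring and a ring nitrogen at once, and these compounds cannot separate the two; phenyl on the same carbonyl carbon would show the ring without that nitrogen, and pyridin-3-yl would show the same ring attached differently. Also open, on these data alone, is how a small chain such as ethyl or a longer one such as butyl would fare in place of the methyl, which would show whether the number climbs gradually with larger groups on this carbon or only with a ring.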